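From chloro to trifluoromethyl: estimating compound 3

The source may hold more compounds than are shown below. What is called first, only, known or untested is meant among the compounds shown, and "the series" means these compounds.

compound 1 `NC(=O)c1cc(-c2ccnc(N)n2)[nH]c1-c1cc(C(F)(F)F)ccc1Cl`: 16.2 mL/min/kg
compound 2 `CCc1ccc(Cl)cc1-c1[nH]c(-c2ccnc(N)n2)cc1C(N)=O`: 94 mL/min/kg

In an ADME assay on the whole organism (strain Balb) for pharmacokinetics, with Mus musculus as the target, at a dose of 10 mg/kg by the intravenous route (a higher number here means faster removal of the compound, a lower number slower removal), compound 2, at 94 mL/min/kg, has the higher of the two numbers, and its gap to compound 1 at 16.2 mL/min/kg lies beyond the usual scatter. Compound 3 `CCc1ccc(C(F)(F)F)cc1-c1[nH]c(-c2ccnc(N)n2)cc1C(N)=O` has not yet been measured. It carries trifluoromethyl in place of chloro on an aromatic carbon, para to an ethyl group: trifluoromethyl in place of chloro on an aromatic carbon. Going by the values given here, the measured compounds include no pair that differs in one place, so the data give no direct guide to this change. Starting from compound 2 at 94 mL/min/kg, no step beyond the scatter is expected in this assay. The expected step of a 1.3-fold lower number from compound 2 to compound 3 (0.10 log units; within the scatter) is small and downward. For compound 3 the estimated clearance is 75 mL/min/kg, with an expected range of 35 mL/min/kg to 130 mL/min/kg.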

Compound 3, clearance: 21.6 mL/min/kg
Beside the measured number, compound 3's estimate is 3.5-fold (0.54 log units) above it, outside the stated range (below it).
By their numbers in this assay, from the lowest: compounds 1 and 3 (each within the scatter of the next); then compound 2.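

In this assay, going by these compounds alone, the aromatic carbon para to an ethyl group proves sensitive to its substituent: trifluoromethyl in place of chloro gives a 4.4-fold lower number from compound 2 to compound 3 (0.64 log units; beyond the scatter), the first direct reading of this change, and a modest one. Within the data shown here, with trifluoromethyl held constant, ethyl in place of chloro on an aromatic carbon gives a 1.3-fold higher number from compound 1 to compound 3 (0.12 log units; within the scatter), so this second exchange leaves the clearance within the scatter in the one pair available. No measurement shown accounts for either step.

The compounds shown leave open how a nitrile, a methoxy group or a single fluorine would behave on the same aromatic carbon. They also leave open whether a longer chain in place of ethyl would keep the clearance close to that of compound 3 at 21.6 mL/min/kg.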